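Ethylcarbamoyl for carbamoyl, carried to the methylphenyl analogue

The compounds below may be only part of what the source reports. "The series", "measured", "known", "first", "only" and "open" are said of these compounds alone.

Compound 1 `NC(=O)N1CCN(C(=S)SCc2cn(Cc3ccc(F)cc3)nn2)CC1` and compound 2 `CCNC(=O)N1CCN(C(=S)SCc2cn(Cc3ccc(F)cc3)nn2)CC1` share a core and differ by ethyl in place of hydrogen on an amide-type nitrogen. In a functional assay on MGC-803 cells (Homo sapiens) for cytotoxicity, read by MTT assay, with a stated time of 72 h (on this read-out lower numbers stand for stronger inhibition and higher numbers for weaker inhibition), compound 1 gives 9330 nM, while compound 2 gives 2170 nM, which is a 4.3-fold lower number from compound 1 to compound 2 (0.63 log units; beyond the scatter). Compound 3 `Cc1ccc(Cn2cc(CSC(=S)N3CCN(C(N)=O)CC3)nn2)cc1` differs from compound 1 by methyl in place of fluoro on an aromatic carbon; in this assay compound 3 gives 29900 nM, a step of a 3.2-fold higher number from compound 1 to compound 3 (0.51 log units; beyond the scatter), and this is the highest number of the three measured compounds, beyond the scatter against both others.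

Compound 4 `CCNC(=O)N1CCN(C(=S)SCc2cn(Cc3ccc(C)cc3)nn2)CC1` is not yet measured. It differs from compound 3 by ethyl in place of hydrogen on an amide-type nitrogen; this is the same change as from compound 1 to compound 2, and the place is described in the same words, so the change is the same and not merely of the same kind. For the measured compounds named here, the one measured instance, a 4.3-fold lower number from compound 1 to compound 2 (0.63 log units; beyond the scatter), is the only basis for the expectation, and a step of similar size is expected, with a 4.0-fold lower number from compound 3 to compound 4 (0.60 log units; beyond the scatter), because of a 4.3-fold lower number from compound 1 to compound 2 (0.63 log units; beyond the scatter). Compound 4 is therefore estimated at 7500 nM, with a range of 3000 nM to 18000 nM.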

Compound 4, half-maximal inhibitory concentration: 19800 nM
Beside the measured number, compound 4's estimate is 2.6-fold (0.42 log units) below it, outside the stated range (above it).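

In this assay, ethyl in place of the amide hydrogen gives a 1.5-fold lower number from compound 3 to compound 4 (0.18 log units; within the scatter), so the clear step seen on the core of compound 1 does not carry over at its size to the core of compound 3: the same change on two cores in this assay, a 4.3-fold lower number (0.63 log units; beyond the scatter) from compound 1 to compound 2 and a 1.5-fold lower number (0.18 log units; within the scatter) from compound 3 to compound 4, 2.8-fold (0.45 log units) apart, beyond the scatter of two such steps. Read the other way, methyl in place of fluoro gives a 9.1-fold higher number from compound 2 to compound 4 (0.96 log units; beyond the scatter) when the ethylcarbamoyl group is present, a larger step than with the carbamoyl group: the same change on two cores in this assay, a 3.2-fold higher number (0.51 log units; beyond the scatter) from compound 1 to compound 3 and a 9.1-fold higher number (0.96 log units; beyond the scatter) from compound 2 to compound 4, 2.8-fold (0.45 log units) apart, beyond the scatter of two such steps. The two changes therefore do not add independently across these four compounds, but this rests on a single set of four and shows neither why the steps differ nor whether other groups would behave the same way.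

The compounds shown leave open whether chloro or methoxy in place of fluoro would keep the ethyl step or lose it, as methyl does. Also open, as far as these compounds go, is whether a methyl or a longer chain such as propyl on the amide-type nitrogen would follow ethyl on each core.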